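This account rests on a few compounds, and the source may have more. Where it says the series, first, only, none or still open, it means among the compounds named here.

Values in an ADME assay on MOLT-3 cells (Homo sapiens) for cytotoxicity, with a stated time of 7 days; on this read-out lower numbers stand for higher toxicity in this test and higher numbers for lower toxicity in this test:
Compound 1 `CCCCCCCCOc1nc(N)nc2c1ncn2/C=C1/CC1(CO)CO`: > 20000 nM
Compound 2 `CN(C)c1nc(N)nc2c1ncn2/C=C1/CC1(CO)CO`: "not determined" (no result reported)
Compound 3 `Nc1nc2c(ncn2/C=C2/CC2(CO)CO)c(=O)[nH]1`: > 20000 nM

Compound 1 gives > 20000 nM, which is a limit of the assay and not a number. Compound 3 gives > 20000 nM, also a limit. Compound 2 has no place on the scale, as its entry reads "not determined" (no result reported). Compound 4 `Nc1nc(NC2CCCC2)c2ncn(/C=C3/CC3(CO)CO)c2n1` is still to be measured. The structural change is cyclopentylamino in place of dimethylamino on an aromatic carbon, with cyclopentylamino in place of dimethylamino on an aromatic carbon. No step beyond the scatter is expected in this assay. That expectation rests on (the limit of > 20000 nM in this assay, at which 2 of the 3 values shown sit). Compound 4 is estimated at 25000 nM, with an expected range of 8000 nM to 60000 nM.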

Compound 4, half-maximal cytotoxic concentration: > 20000 nM
Compound 4 ended at the assay's limit (the forecaster's own chance of this, stated with the estimate: 75%); the middle value does not contradict the limit.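

Among these compounds, compound 1 and compound 4 both stand at a limit, not a number, in this assay, and no step between them can be read. The compounds shown leave open whether any group on the shared core brings measurable toxicity in this test.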